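The source may hold more compounds than are shown below. What is called first, only, known or untested is meant among the compounds shown, and "the series" means these compounds.

Values in an ADME assay on HepG2 cells (Homo sapiens) for cytotoxicity, in the presence of a further agent that is not named here (on this read-out higher numbers stand for weaker inhibition and lower numbers for stronger inhibition), each a limit of the assay and not a number:

Compound 1 `Cn1c(Cc2ccccc2C(F)(F)F)nc(C(=O)NCC2CCCCC2)c(O)c1=O` gives > 100000 nM
Compound 2 `CC(c1ccccc1C(F)(F)F)c1nc(C(=O)NCc2ccccc2)c(O)c(=O)n1C` gives > 100000 nM
Compound 3 `COc1c(C(=O)NCc2ccccc2)nc(Cc2ccccc2C(F)(F)F)n(C)c1=O` gives > 100000 nM

Compound 1 therefore stands at a limit and has no exact number. All three compounds share this position, with the limit of > 100000 nM in this assay, at which 3 of the 3 values shown sit. Compound 4 `Cn1c(Cc2ccccc2C(F)(F)F)nc(C(=O)NCc2ccccc2F)c(O)c1=O` is still to be measured. It differs from compound 1 by 2-fluorophenyl in place of cyclohexyl on a saturated chain carbon bound to an amide-type nitrogen, with 2-fluorophenyl in place of cyclohexyl on a saturated chain carbon bound to an amide-type nitrogen. Among the measured compounds shown here, no measured step shows the size of such a change. The estimated a number no higher from compound 1 to compound 4 (the limit leaves the size open) is expected to stay within the scatter, with no direction expected, because of the limit of > 100000 nM in this assay, at which 3 of the 3 values shown sit. Compound 4 is estimated at 100000 nM, with an expected range of 50000 nM to 200000 nM.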

Compound 4, half-maximal inhibitory concentration: > 100000 nM
Compound 4: a limit, no number; the forecaster's own chance of this, stated with the estimate: 90%; the middle value lies on the limit itself.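

Compound 4 gives > 100000 nM, a limit of the assay and not a number. With a limit on both sides, no step can be read between compound 1 and compound 4. The compounds shown leave open how any of them would rank by an exact value in this assay.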